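This account rests on a few compounds, and the source may have more. Where it says the series, first, only, none or still open, it means among the compounds named here.

In a physicochemical assay for solubility, at pH 7.4 (on this read-out higher numbers stand for higher solubility and lower numbers for lower solubility), compound 3 (`Cc1c2c(n3c1CCN(C(=O)CN)C[C@@H](C)[C@H](C)Nc1cc-3ccc1C(N)=O)CC(C)(C)CC2=O`) gives 46 ug/mL. Compound 2 (`CC(=O)N1CCc2c(C)c3c(n2-c2ccc(C(N)=O)c(c2)N[C@@H](C)[C@H](C)C1)CC(C)(C)CC3=O`) gives 38 ug/mL, so the two numbers stand level. The gap between them is a 1.2-fold higher number from compound 2 to compound 3 (0.08 log units; within the scatter), and it comes with amino in place of hydrogen on a saturated chain carbon bound to a carbonyl carbon. Compound 1 (`Cc1c2c(n3c1CCN(C(=O)[C@H](C)N)CC[C@H](C)Nc1cc-3ccc1C(N)=O)CC(C)(C)CC2=O`) is reported only as a limit, > 100 ug/mL, and this is not a number. Compound 3 therefore has one measured neighbour at its own level and one compound known only by a limit.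

Compound 4 (`CC[C@H](N)C(=O)N1CCc2c(C)c3c(n2-c2ccc(C(N)=O)c(c2)N[C@@H](C)[C@H](C)C1)CC(C)(C)CC3=O`) has not yet been measured in this assay. It carries ethyl in place of hydrogen on a saturated chain carbon bound to an amine nitrogen and a carbonyl carbon. Going by the values given here, no measured step makes this same change. The closest guide is the change at that chain carbon, a 1.2-fold higher number from compound 2 to compound 3 (0.08 log units; within the scatter), which stayed within the scatter. Among the compounds with values here, the limit of compound 1 gives no size of step, and it leaves the upper side of the expectation open. The expected step is therefore small, a 1.3-fold higher number from compound 3 to compound 4 (0.12 log units; within the scatter), with no shift beyond the scatter. The estimate for compound 4 is 60 ug/mL, with an expected range from 25 ug/mL to 140 ug/mL.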

Compound 4, solubility: > 100 ug/mL
Compound 4: a limit, no number; the forecaster's own chance of this, stated with the estimate: 25%; middle value at least 1.6-fold (0.22 log units) away from the limit.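

In this assay, going by these compounds alone, ethyl in place of hydrogen on a saturated chain carbon bound to an amine nitrogen and a carbonyl carbon comes with a step beyond the scatter, an at least 2.1-fold higher number from compound 3 to compound 4 (0.33 log units; beyond the scatter), whereas the only earlier step at this chain carbon, a 1.2-fold higher number from compound 2 to compound 3 (0.08 log units; within the scatter), stayed within it. Read as a single change on the carbonyl carbon, 1-aminopropyl in place of methyl also gives a step beyond the scatter, an at least 2.6-fold higher number from compound 2 to compound 4 (0.42 log units; beyond the scatter), so this position can move the read-out once the ethyl stands there with the amino group. Both sizes are only lower bounds and the full size of either step cannot be read, as compound 4 is reported as a limit and not a number: the limit of > 100 ug/mL in this assay, at which 2 of the 4 values shown sit.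

The compounds shown leave open whether a longer chain such as butyl, or a phenyl ring, on the same carbon would go with a number at this level. They also leave open whether the step would survive if a hydroxyl group or a carboxylic acid took the place of the amine on that carbon.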